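The source may report more compounds than this note shows. Statements on the series, on what has been measured and on what is new or still open speak of the compounds shown alone.

Compound 1 `[O-][S+](Cc1ccccc1)c1nnc(-c2ccncc2)o1` gives 3000 nM in a functional assay on HUVEC cells (Homo sapiens) for inhibition, read by ELISA (on this read-out higher numbers stand for weaker inhibition and lower numbers for stronger inhibition), the lower of the two numbers on record, and compound 2 `CCc1nnc([S+]([O-])Cc2ncc(C)c(OC)c2C)o1` gives 10000 nM in this assay, a gap that lies beyond the scatter. Compound 3 `[O-][S+](Cc1ccccc1)c1nnc(-c2ccccc2O)o1` differs from compound 1 by 2-hydroxyphenyl in place of pyridin-4-yl on an aromatic carbon. Among the measured compounds shown here, no measured pair shows this change, so only an expectation can be offered. The step of no change at the digits printed from compound 1 to compound 3 (within the scatter) is expected to be small, not beyond the scatter in either direction. Compound 3 is therefore estimated at 3000 nM in this assay, within a range from 800 nM to 12000 nM.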

Compound 3, half-maximal inhibitory concentration: 6000 nM
The estimate for compound 3 lay 2.0-fold (0.30 log units) below the measured number; low and high end bracket the measured number.
By their numbers in this assay, from the lowest: compounds 1, 3 and 2 (each within the scatter of the next, the first and the last beyond it).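

In this assay, 2-hydroxyphenyl in place of pyridin-4-yl gives a 2.0-fold higher number from compound 1 to compound 3 (0.30 log units; within the scatter), so this aromatic carbon tolerates the loss of the ring nitrogen and the entry of a hydrogen-bond donor without a step beyond the scatter. The ring at this place can thus be of carbon only. Nothing measured explains why the two groups read so alike. From the compounds shown here alone, it remains open whether plain phenyl would read like compound 3. Going by these compounds, whether an amine or a carboxylic acid on this aromatic carbon would move the number beyond the scatter also remains open.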